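Swapping the pyrrole for a nitrile on the chromene core

This account rests on a few compounds, and the source may have more. Where it says the series, first, only, none or still open, it means among the compounds named here.

Measured compounds:
compound 1 `CCC(=O)c1ccc2c(c1)C(n1ccccc1=O)=CC(C)(C)O2` gives 5.85
compound 2 `Cc1ccc(C)n1-c1ccc2c(c1)C(n1ccccc1=O)=CC(C)(C)O2` gives 6.78

Both compounds were tested in a functional assay (trachea) with Rattus norvegicus as the target; on this read-out lower numbers stand for lower potency and higher numbers for higher potency (the scale is a negative logarithm). Compound 2 stands highest of the two numbers; its nearest neighbour is compound 1, and the step of a number 0.93 log units higher from compound 1 to compound 2 (beyond the scatter) shows that replacing propanoyl with 2,5-dimethyl-1H-pyrrol-1-yl raised potency clearly.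

Compound 3 `CC1(C)C=C(n2ccccc2=O)c2cc(C#N)ccc2O1` is not yet measured. It differs from compound 2 as follows: cyano in place of 2,5-dimethyl-1H-pyrrol-1-yl on an aromatic carbon. For the measured compounds named here, the only measured step touches the same aromatic carbon, but it compares propanoyl with the pyrrole, not the pyrrole with cyano, so it gives no direct guide to the size or direction of the new change. The shared core stays untouched. With a single step to lean on, the estimate for compound 3 is expected to sit near compound 2, with a wide range, and the expected step is a number 0.08 log units lower from compound 2 to compound 3 (within the scatter), which is within the usual scatter. Compound 3 is therefore expected to give about 6.7, between 5.9 and 7.5, in this assay.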

Compound 3, logarithm of the reciprocal of the active concentration, log(1/C): 7.1
Beside the measured number, compound 3's estimate is 0.40 log units below it; low and high end bracket the measured number.
By their numbers in this assay, from the lowest: compound 1; then compound 2; then compound 3.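

At this aromatic carbon, the five-membered ring of the 2,5-dimethyl-1H-pyrrol-1-yl group is not needed for potency in this assay: exchanging it for the much smaller cyano group gives a number 0.32 log units higher from compound 2 to compound 3 (beyond the scatter). Cyano also compares well with propanoyl, with a number 1.25 log units higher from compound 1 to compound 3 (beyond the scatter), so compound 3 stands as the most potent of the three, and the ring-free cyano group outperforms both earlier groups at this position. Having a ring does not by itself order the three groups, however, since compound 1 also carries a group without a ring at this carbon and still ranks lowest, and no available evidence accounts for this ranking.

The compounds shown leave open how an amine, a carboxylic acid or a longer chain such as butanoyl would compare with cyano at this aromatic carbon. They also leave open whether cyano would keep its advantage over the other two groups if the shared core were changed elsewhere.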